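The source may hold more compounds than are shown below. What is called first, only, known or untested is meant among the compounds shown, and "the series" means these compounds.

Measured to date in a functional assay on ACHN cells (Homo sapiens) for cytotoxicity, read by sulforhodamine B assay, with a stated time of 48 h, tested at 1 uM; on this read-out lower numbers stand for a stronger effect and higher numbers for a weaker effect at the one concentration tested:
compound 1 `COc1ccc(-c2cc(/C=C/C(=O)c3ccc(N)cc3)[nH]n2)cc1` gives 71%
compound 2 `COc1cc(-c2cc(/C=C/C(=O)c3ccc(N)cc3)[nH]n2)cc(OC)c1OC` gives 79%
compound 3 `COc1cc(-c2cc(/C=C/C(=O)c3ccc(Cl)c(Cl)c3)[nH]n2)cc(OC)c1OC` gives 101%

Compound 2 stands second highest of the three numbers. Its nearest neighbour is compound 1, within the scatter; its furthest is compound 3, with the step of a number 22 percentage points higher from compound 2 to compound 3 (beyond the scatter) for 3,4-dichlorophenyl in place of 4-aminophenyl on a carbonyl carbon. Next is compound 4 `COc1ccc(-c2cc(/C=C/C(=O)c3ccc(N)cc3)[nH]n2)cc1OC`, which differs from compound 2 by hydrogen in place of methoxy on an aromatic carbon. Going by the values given here, no measured step touches the methoxy groups: the one recorded step alters the other end of the molecule, and compound 1, which differs from compound 2 only in methoxy pattern, sits within the scatter of compound 2. Compound 4 is therefore expected to show no step beyond the scatter, a number 4 percentage points lower from compound 2 to compound 4 (within the scatter). For compound 4 the estimate in this assay is 75%, within 62% to 90%.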

Compound 4, a percentage reported as activity, at one concentration (the size of the read-out at that concentration, not a potency): 88%
Estimate against measurement, compound 4: 13 percentage points below; low and high end bracket the measured number.
By their numbers in this assay, from the lowest: compounds 1, 2 and 4 (each within the scatter of the next, the first and the last beyond it); then compound 3.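

In this assay, going by these compounds alone, hydrogen in place of methoxy on this aromatic carbon gives a number 9 percentage points higher from compound 2 to compound 4 (within the scatter), while methoxy in place of hydrogen on an aromatic carbon gives a number 17 percentage points higher from compound 1 to compound 4 (beyond the scatter), the first step on this ring beyond the scatter. Substitution on this ring can therefore shift the read-out modestly, but no steady rise with each added methoxy can be read, as compound 2 goes against one. Nothing available accounts for this difference.

Still open, as far as these compounds go, is whether a hydroxyl or a fluorine at this position would behave like methoxy or hydrogen. Also open, from the compounds shown here alone, is whether these ring changes carry over to compounds with the 3,4-dichlorophenyl group.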